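The source may report more compounds than this note shows. Statements on the series, on what has been measured and on what is new or still open speak of the compounds shown alone.

Measured compounds:
Compound 1, `Cc1ccc(S(=O)(=O)n2cc(-c3cc(C(F)(F)F)ccn3)c3cc(Br)ccc32)cc1`: in a functional assay on A549 cells (Homo sapiens) for cytotoxicity (on this read-out higher numbers stand for weaker inhibition and lower numbers for stronger inhibition), compound 1 gives 4100 nM.
Compound 2, `Cc1ccc(S(=O)(=O)n2cc(-c3cc(C(F)(F)F)ccn3)c3cc(OCc4ccccc4)ccc32)cc1`: in this assay compound 2 reaches only a limit of the assay, > 100000 nM.
Compound 3, `Cc1ccc(S(=O)(=O)n2cc(-c3cc(C(F)(F)F)cc(-c4cn(S(=O)(=O)c5ccc(C)cc5)c5ccccc45)n3)c3ccccc32)cc1`: in this assay compound 3 gives 23000 nM.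

Compound 2 thus stands at the weak end of the three: its result is not a number but a limit, (the limit of > 100000 nM in this assay, at which 1 of the 3 values shown sits). Within the data shown here, the one measured step that touches compound 2 is an at least 24-fold higher number from compound 1 to compound 2 (1.38 log units; beyond the scatter), where bromo on an aromatic carbon gave way to benzyloxy. Compound 4, `COc1ccc2c(c1)c(-c1cc(C(F)(F)F)ccn1)cn2S(=O)(=O)c1ccc(C)cc1`, is now to be measured. Compared with compound 2 it carries the change (hydrogen in place of phenyl on a saturated chain carbon bound to an oxygen on an aromatic ring), so that benzyloxy becomes methoxy. This partly undoes the step from compound 1 to compound 2 by cutting the larger group back, though bromo is not restored. Since the measured step ran toward a weaker result when benzyloxy entered, the expectation for compound 4 is a move back toward a stronger result, yet only part of the way, and the limit leaves the size of that move uncertain. The expected step is an at least 3.3-fold lower number from compound 2 to compound 4 (0.52 log units; beyond the scatter). Compound 4 is therefore estimated at 30000 nM in this assay, within the range 8000 nM to 150000 nM.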

Compound 4, half-maximal inhibitory concentration: > 100000 nM
Compound 4 was reported as a limit; the forecaster's own chance of this, stated with the estimate: 35%; middle value at least 3.3-fold (0.52 log units) away from the limit.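

In this assay compound 4 reaches only a limit of the assay, > 100000 nM, so cutting benzyloxy back to methoxy restores no measurable inhibition at this position. Methoxy in place of bromo gives an at least 24-fold higher number from compound 1 to compound 4 (1.38 log units; beyond the scatter), which shows that the loss seen with compound 2 does not depend on the phenyl ring of benzyloxy: among these compounds, both oxygen-linked groups go with a far weaker result than bromo. Compound 2 and compound 4 both end at a limit, so the step between them cannot be read and neither group can be ranked against the other: the limit of > 100000 nM in this assay, at which 2 of the 4 values shown sit.

The compounds shown leave open whether bromo is unusual at this place or whether other groups, such as chloro, a nitrile or an amine, would also give a measurable value in this assay. They also leave open how much weaker than compound 1 the methoxy and benzyloxy compounds really are, and whether a free hydroxy group on the same carbon would behave like the two oxygen-linked groups or like bromo.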